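Cytotoxicity notes on a small series, with one estimate

The source may hold more compounds than are shown below. What is called first, only, known or untested is meant among the compounds shown, and "the series" means these compounds.

Measured so far:
compound 1, `CC(C)NC(=N)c1ccc2oc(-c3cccc(OCCCOc4ccccc4)c3)cc2c1`, gives 26500 nM
compound 2, `c1ccc(OCCCOc2cccc(-c3cc4cc(C5=NCCN5)ccc4o3)c2)cc1`, gives 6500 nM
compound 3, `CC(C)NC(=N)c1ccc2oc(-c3ccc(OCCCOc4ccccc4)cc3)cc2c1`, gives 45600 nM

All three numbers come from an ADME assay on L6 cells (Rattus norvegicus) for cytotoxicity, read by resazurin assay, with a stated time of 70 h; a higher number here means a weaker inhibitor, a lower number a stronger inhibitor. Compound 1 and compound 2 differ in one place: a group of 5 heavy atoms (3 carbon, 2 nitrogen; one five-membered non-aromatic ring with 2 hetero atoms) in place of a group of 6 heavy atoms (4 carbon, 2 nitrogen; no ring), on an aromatic carbon. This change gives a 4.1-fold lower number from compound 1 to compound 2 (0.61 log units; beyond the scatter). Compound 3 has the same atoms as compound 1, joined differently; the difference between the two cores is not broken down here. The values of compound 3 and compound 1 lie within the scatter of each other, so no order between them is read. Compound 2 gives the lowest number of the three, and its gap to compound 3 is beyond the scatter.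

Compound 4, `c1ccc(OCCCOc2ccc(-c3cc4cc(C5=NCCN5)ccc4o3)cc2)cc1`, is not yet measured. It stands to compound 3 as compound 2 stands to compound 1: a group of 5 heavy atoms (3 carbon, 2 nitrogen; one five-membered non-aromatic ring with 2 hetero atoms) in place of a group of 6 heavy atoms (4 carbon, 2 nitrogen; no ring), on an aromatic carbon. The place of the change is the same in both pairs, so this is the same change, seen twice among the compounds shown. Among the compounds with values here, with only one measured example, the expectation for compound 4 rests on compound 1 and compound 2 alone, because a 4.1-fold lower number from compound 1 to compound 2 (0.61 log units; beyond the scatter) is the single step of this kind on hand; a step of about a 4.1-fold lower number from compound 3 to compound 4 (0.62 log units; beyond the scatter) is expected from compound 3 to compound 4 in this assay. Applied to compound 3, this leads to an estimated 11000 nM for compound 4, with an expected range from 5000 nM to 25000 nM.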

Compound 4, half-maximal inhibitory concentration: 10300 nM
Compound 4: the middle estimate sits 1.1-fold (0.03 log units) above what was measured; low and high end bracket the measured number.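

In this assay the five-membered non-aromatic ring with 2 hetero atoms, in place of the open group of 6 heavy atoms on the same aromatic carbon, gives a 4.4-fold lower number from compound 3 to compound 4 (0.65 log units; beyond the scatter) and so repeats the earlier step on a second core: the same change on two cores in this assay, a 4.1-fold lower number (0.61 log units; beyond the scatter) from compound 1 to compound 2 and a 4.4-fold lower number (0.65 log units; beyond the scatter) from compound 3 to compound 4, 1.1-fold (0.04 log units) apart, within the scatter of two such steps. Within these two matched pairs the change can therefore be carried from the core of compound 1 to the core of compound 3 with no readable difference in the size of the step, even though those two cores hold the same atoms joined differently. This shows agreement across two cores in one cell assay only; it does not show that the step would hold on any further core, and it gives no explanation for the lower number.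

The compounds shown leave open what other groups at that aromatic carbon would give, for example an amine, a carboxylic acid or a longer chain in place of the two groups compared here. They also leave open whether the same step would appear in any read-out other than this assay.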